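Liver-Cell Inhibition: Ethoxy in Place of Fluoro

This account rests on a few compounds, and the source may have more. Where it says the series, first, only, none or still open, it means among the compounds named here.

Compound 1 `COc1ccc2c(=O)c(/C=C/C(=O)NCc3ccc(C)cc3)coc2c1`: in a functional assay on L02 cells (Homo sapiens) for inhibition, read by MTT assay, with a stated time of 48 h (a higher number here means a weaker inhibitor, a lower number a stronger inhibitor), compound 1 gives > 200000 nM, which is a limit of the assay and not a number.
Compound 2 `COc1ccc2c(=O)c(/C=C/C(=O)Nc3ccc(F)cc3)coc2c1`: in this assay compound 2 gives > 200000 nM, again a limit rather than a number.

Going by the values given here, compound 2 therefore cannot be placed at a definite point; all that is known is that it sits at the limit, and the one other value shown is a limit as well. Among the compounds with values here, the only measured step, a step that the two limits leave unreadable from compound 1 to compound 2, cannot be read for the same reason, since (the limit of > 200000 nM in this assay, at which 2 of the 2 values shown sit).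

Compound 3 `CCOc1ccc(NC(=O)/C=C/c2coc3cc(OC)ccc3c2=O)cc1` differs from compound 2 by one change: ethoxy in place of fluoro on an aromatic carbon. Within the data shown here, no measured step shows what such a change does in this assay, and the one step that exists is unreadable. With both measured compounds sitting at the limit, the most likely outcome is that compound 3 sits there too. Expected for this change is a step of a number no higher from compound 2 to compound 3 (the limit leaves the size open), none beyond the scatter. For compound 3 the expected value in this assay is 200000 nM, within a range from 100000 nM to 400000 nM.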

Compound 3, half-maximal inhibitory concentration: > 200000 nM
Compound 3 was reported as a limit; the forecaster's own chance of this, stated with the estimate: 80%; the middle value sits exactly at the limit.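

In this assay compound 3 gives > 200000 nM, which is a limit and not a number. No step among compound 1, compound 2 and compound 3 can be read, because none of them has a definite value to compare: the limit of > 200000 nM in this assay, at which 3 of the 3 values shown sit.

The compounds shown leave open how strongly any of them inhibits these cells, and what ethoxy in place of fluoro does in this assay.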